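Phenyl for Butyl on the Ring Nitrogen of a Thiazolethione

The source may hold more compounds than are shown below. What is called first, only, known or untested is meant among the compounds shown, and "the series" means these compounds.

Going by the values given here, compound 2, `CCCCn1c(/N=C/c2ccc(Br)cc2)c(C#N)sc1=S`, sits at the higher end of the two numbers so far: in an assay on HEK293 cells for displacement of a labelled ligand from adenosine receptor A1 (Homo sapiens), read by scintillation counting, with a stated time of 60 min (on this read-out higher numbers stand for weaker inhibition and lower numbers for stronger inhibition), compound 2 gives 0.1 nM, whereas compound 1, `CCn1c(/N=C/c2ccc(Br)cc2)c(C#N)sc1=S`, gives 0.00074 nM. Among the compounds with values here, the one step that has been measured, a 140-fold higher number from compound 1 to compound 2 (2.13 log units; beyond the scatter), is the only guide available, and it concerns a change in the length of the saturated chain rather than an exchange of chain for ring. Compound 3, `N#Cc1sc(=S)n(-c2ccccc2)c1/N=C/c1ccc(Br)cc1`, is obtained by phenyl in place of butyl on an aromatic nitrogen. Within the data shown here, no measured pair shows what replacing an alkyl chain by an aromatic ring on this nitrogen does, so the direction of the change is open; the lengthening step from compound 1 to compound 2 only shows that this position is sensitive. On that basis the step from compound 2 to compound 3 in this assay is expected to be modest in size and weighted slightly toward a higher number, a 3.0-fold higher number from compound 2 to compound 3 (0.48 log units; beyond the scatter). The value of compound 3 in this assay is therefore estimated at 0.3 nM, within a range from 0.03 nM to 3 nM.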

Compound 3, inhibition constant: 186 nM
Compound 3: the middle estimate sits 620-fold (2.79 log units) below what was measured, and the stated range ends below it.
By their numbers in this assay, from the lowest: compound 1; then compound 2; then compound 3.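

In this assay, the nitrogen that had so far been shown to respond to chain length also responds strongly to an exchange of chain for ring: phenyl in place of butyl gives a 1900-fold higher number from compound 2 to compound 3 (3.27 log units; beyond the scatter) and places compound 3 at the top of the three numbers. Going by these compounds alone, measured against the short ethyl chain, the same ring gives a 250000-fold higher number from compound 1 to compound 3 (5.40 log units; beyond the scatter) and so spans the whole range seen at this position, with ethyl, butyl and phenyl rising in that order and no compound among the three going against this order. No measurement given here accounts for the size of these steps or shows why the aromatic ring raises the number so sharply.

The compounds shown leave open whether the rise follows from the aromatic ring itself or from its direct attachment to the nitrogen, a question that a benzyl or cyclohexyl group at this position would address. They also leave open how methyl, propyl or a longer chain such as hexyl would fall in the order set by the ethyl and butyl chains.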